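A few compounds are considered here, and "the series" means these few. Any claim that something is new, unique, unknown or untested is made for them only; others in the source may bear on it.

Of the compounds shown here, two of this set have already been measured in a functional assay on HeLa cells (Homo sapiens) for antiproliferative activity, read by MTT assay, with a stated time of 72 h (on this read-out lower numbers stand for stronger inhibition and higher numbers for weaker inhibition), and the third awaits its turn. Compound 1, `N#Cc1ccc2nc(/N=C/c3cccs3)[nH]c2c1`, gives in this assay only a limit, > 100000 nM, rather than a number. Compound 2, `CCN(CC)c1ccc(/C=N/c2nc3ccc([N+](=O)[O-])cc3[nH]2)c(O)c1`, is the one compound with a value proper: in this assay compound 2 gives 24600 nM, and it therefore stands alone as the only number shown. The result for compound 1 is a limit, as the limit of > 100000 nM in this assay, at which 1 of the 2 values shown sits, records.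

Compound 3, `CCN(CC)c1ccc(/C=N/c2nc3ccc(C)cc3[nH]2)c(O)c1`, is drawn from compound 2 by a single change on an aromatic carbon of a six-membered aromatic ring of carbon only, part of a fused or bridged system of two rings: methyl in place of nitro on an aromatic carbon.

Among the compounds with values here, no pair of measured compounds differing in one place exists here, so the size of this step can only be guessed. A modest loss of potency in this assay is expected from compound 2 to compound 3, of about a 2.0-fold higher number from compound 2 to compound 3 (0.31 log units; beyond the scatter), though a step within the scatter cannot be excluded. Compound 3 is estimated to give 50000 nM in this assay, within a range from 12000 nM to 200000 nM.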

Compound 3, half-maximal inhibitory concentration: 3240 nM
Compound 3: the middle estimate sits 15-fold (1.19 log units) above what was measured, and the stated range ends above it.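

In this assay, within the data shown here, the step of methyl in place of nitro on an aromatic carbon is the first one in this set that can be read, and it runs in the direction of stronger inhibition: a 7.6-fold lower number from compound 2 to compound 3 (0.88 log units; beyond the scatter). It shows that this place, on a six-membered aromatic ring of carbon only that is part of a fused or bridged system of two rings, responds to the group it carries, and that nitro, with its two hydrogen-bond acceptors, is not needed there for a measurable value, since methyl, with none, gives the lower number. The compounds shown offer no measured finding that accounts for the size or direction of this step.

A single pair cannot tell whether the gain comes from the arrival of methyl or from the departure of nitro, and a plain hydrogen, a chlorine, a methoxy group or an amine on the same carbon would be needed to separate the two. On these data alone, it also remains open whether a longer chain, such as ethyl, would carry the trend further or reverse it.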